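This account rests on a few compounds, and the source may have more. Where it says the series, first, only, none or still open, it means among the compounds named here.

Compound 1 `CCOc1nc2cccc(C(=O)Nc3ccccc3)c2n1Cc1ccc(-c2ccccc2-c2nnn[nH]2)cc1`: 34.6%
Compound 2 `CCOc1nc2cccc(C(=O)Nc3ccncc3)c2n1Cc1ccc(-c2ccccc2-c2nnn[nH]2)cc1`: 39.8%

In an assay on isolated protein for inhibition of NEDD8-activating enzyme E1 regulatory subunit (Homo sapiens), read by Western blot, with stated times of 10 min and 30 min, tested at 25 uM (on this read-out lower numbers stand for less inhibition and higher numbers for more inhibition at the one concentration tested (going by the name of the read-out)), compound 2 gives 39.8%, while compound 1 gives 34.6%; the step of a number 5.2 percentage points higher from compound 1 to compound 2 (within the scatter) lies within the scatter, so the two cannot be told apart. Compound 3 `CCOc1nc2cccc(C(=O)NCc3ccco3)c2n1Cc1ccc(-c2ccccc2-c2nnn[nH]2)cc1` differs from compound 2 by (furan-2-yl)methyl in place of pyridin-4-yl on an amide-type nitrogen. Going by the values given here, the single measured step, which also swapped one aromatic ring for another on the same amide-type nitrogen, stayed within the scatter, so no step beyond the scatter is expected here; the expected step is a number 4.8 percentage points lower from compound 2 to compound 3 (within the scatter). Compound 3 is therefore estimated at 35%, with a range from 18% to 52%.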

Compound 3, a percentage reported as inhibition, at one concentration (the size of the read-out at that concentration, not a potency): 37.5%
Beside the measured number, compound 3's estimate is 2.5 percentage points below it, within the range that was stated.
By their numbers in this assay, from the lowest: compounds 1, 3 and 2 (each within the scatter of the next).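

Compound 3 shows that this amide-type nitrogen can carry more than a six-membered aromatic ring placed directly on it. In this assay, (furan-2-yl)methyl, with its five-membered aromatic ring, gives a number 2.3 percentage points lower from compound 2 to compound 3 (within the scatter) and a number 2.9 percentage points higher from compound 1 to compound 3 (within the scatter) so it cannot be told apart from either pyridin-4-yl or phenyl.

Still open, going by these compounds, is whether any group here moves the number beyond the scatter, since all three groups carry an aromatic ring and none is an amine, a carboxylic acid or a plain longer carbon chain. No supporting data explain why these three groups read alike.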